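The source may report more compounds than this note shows. Statements on the series, on what has been measured and on what is new or still open speak of the compounds shown alone.

Compound 3 (`CCCCCCCNC[C@@H]1OC[C@H](N)[C@H]1O`) gives > 128000 nM in a functional assay on PC-3 cells (Homo sapiens) for antiproliferative activity, read by MTT assay, with a stated time of 72 h; on this read-out lower numbers stand for stronger inhibition and higher numbers for weaker inhibition. That value is a limit of the assay and not a number, and its place on the scale is (the limit of > 128000 nM in this assay, at which 1 of the 3 values shown sits).

Compound 4 (`CCCCCCCCNC[C@@H]1OC[C@H](N)[C@H]1O`) differs by one small change (methyl in place of hydrogen on a saturated chain carbon, seven bonds along the chain from an amine nitrogen), with methyl in place of hydrogen on a saturated chain carbon, seven bonds along the chain from an amine nitrogen. For the measured compounds named here, only one measured step touches this same carbon. Compound 2 (`CCCCCCCCCCCCNC[C@@H]1OC[C@H](N)[C@H]1O`) gives 2380 nM in this assay and carries a longer chain there. Replacing its pentyl with hydrogen was a large change (an at least 53-fold higher number from compound 2 to compound 3 (1.73 log units; beyond the scatter)), well beyond the scatter. Read in reverse, that step means that chain added at this carbon lowers the number, which stands for stronger inhibition.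

Compound 4 regains only the first carbon of that pentyl, so only part of the step should return. Compound 1 (`CCCCCCCCNC[C@@H]1OC[C@H](N)[C@@H]1O`) gives 13800 nM in this assay and offers a further guide, as its structure shows when set against that of compound 4. The expected move in this assay is downward (an at least 4.2-fold lower number from compound 3 to compound 4 (0.63 log units; beyond the scatter)), and its size stays uncertain, as compound 3 offers only a limit. Compound 4 is expected at 30000 nM (estimated range 10000 nM to 110000 nM).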

Compound 4, half-maximal inhibitory concentration: 13000 nM
Compound 4: the middle estimate sits 2.3-fold (0.36 log units) above what was measured; low and high end bracket the measured number.
By their numbers in this assay, from the lowest: compound 2; then compounds 4 and 1 (each within the scatter of the next). At a limit, above all of these: compound 3.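

Methyl in place of hydrogen on this chain carbon is enough to bring a measurable number in this assay, giving an at least 9.8-fold lower number from compound 3 to compound 4 (0.99 log units; beyond the scatter), and this size is only a bound, as the value for compound 3 is a limit and not a number: the limit of > 128000 nM in this assay, at which 1 of the 4 values shown sits.

That one carbon does not return the full effect of the chain, since hydrogen in place of butyl on a saturated chain carbon, eight bonds along the chain from an amine nitrogen, still gives a 5.5-fold higher number from compound 2 to compound 4 (0.74 log units; beyond the scatter). With this chain, the configuration at a saturated ring carbon leaves the number in this assay within the scatter, at a 1.1-fold lower number from compound 1 to compound 4 (0.03 log units; within the scatter), and the comparison touches nothing else: the fact that compounds 1 and 4 differ only in the configuration as drawn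

The compounds shown do not tell whether the number falls evenly or abruptly as the chain grows through the steps from methyl to ethyl, ethyl to propyl and propyl to butyl, or whether a chain longer than that of compound 2 would lower it further. They also leave open whether an amine or a carboxylic acid in place of the methyl would be tolerated on this carbon.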